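Solubility notes on the step to compound 3

The source may report more compounds than this note shows. Statements on the series, on what has been measured and on what is new or still open speak of the compounds shown alone.

- Compound 1 `Cn1cc(-c2ccc(N(C(=O)NCc3ccccc3)[C@H]3CC[C@H](Nc4ccc(C#N)cn4)CC3)cc2)cn1`: 0.33 ug/mL
- Compound 2 `N#Cc1ccc(N[C@H]2CC[C@H](N(C(=O)NCc3ccccc3)c3ccc(-c4cccnc4)cc3)CC2)nc1`: 0.67 ug/mL
- Compound 3 `Cn1cccc(-c2ccc(N(C(=O)NCc3ccccc3)[C@H]3CC[C@H](Nc4ccc(C#N)cn4)CC3)cc2)c1=O`: not yet measured

In a physicochemical assay for solubility, read by spectrophotometry, at pH 6.8 (a higher number here means a more soluble compound, a lower number a less soluble compound), compound 2 has the higher of the two measured numbers, at 0.67 ug/mL. The change to compound 3 is a group of 8 heavy atoms (6 carbon, 1 nitrogen, 1 oxygen; one six-membered aromatic ring with 1 hetero atom) in place of a group of 6 heavy atoms (5 carbon, 1 nitrogen; one six-membered aromatic ring with 1 hetero atom), on an aromatic carbon. Among the compounds with values here, one measured step bears on it: a 2.0-fold higher number from compound 1 to compound 2 (0.31 log units; beyond the scatter), a modest step that also exchanges the group on an aromatic carbon. A single step is thin evidence, and it does not fix the direction here. A small upward move, and none beyond the scatter, is expected in this assay. The expected step is a 1.5-fold higher number from compound 2 to compound 3 (0.17 log units; within the scatter). The estimate for compound 3 is 1 ug/mL, with an expected range of 0.3 ug/mL to 3.5 ug/mL.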

Compound 3, solubility: 4.7 ug/mL
Compound 3: middle estimate off by 4.7-fold (0.67 log units), on the low side, and the stated range ends below it.
By their numbers in this assay, from the lowest: compound 1; then compound 2; then compound 3.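

In this assay, placing the group of 8 heavy atoms on the aromatic carbon para to a large group gives a 7.0-fold higher number from compound 2 to compound 3 (0.85 log units; beyond the scatter), and measured against the five-membered ring it gives a 14-fold higher number from compound 1 to compound 3 (1.15 log units; beyond the scatter). This position therefore spans a much wider range of numbers than the first pair alone showed, with the group of 8 heavy atoms highest of the three. No available data explain this rise.

Open, from the compounds shown here alone, is whether an amine or a carboxylic acid on this aromatic carbon would take the number higher still. Also open, going by these compounds, is whether the step would carry over to changes elsewhere on the shared core.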